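Compound 4: propyl in place of isopropyl

The compounds below may be only part of what the source reports. "The series", "measured", "known", "first", "only" and "open" are said of these compounds alone.

Measured in an ADME assay on a cell-free system (plasma, Rattus norvegicus), with a stated time of 60 min; a higher number here means that more of the compound is left, a lower number that less of the compound is left:
Compound 1 `O=C(O)c1cc(-c2cccc(COc3ccc4c(c3)CN(c3ccccc3)C4=O)c2)ccc1Cl`: 100%
Compound 2 `CC(C)N1Cc2cc(OCc3cccc(-c4ccc(Cl)c(C(=O)O)c4)c3)ccc2C1=O`: 98%
Compound 3 `O=C(O)c1cc(-c2cccc(COc3ccc4c(c3)CCN(C3CCCC3)C4=O)c2)ccc1Cl`: 100%

Compound 2, at 98%, cannot be told apart from the other two compounds, as all three lie within the scatter of one another. Compound 4 `CCCN1Cc2cc(OCc3cccc(-c4ccc(Cl)c(C(=O)O)c4)c3)ccc2C1=O` has not yet been measured. It differs from compound 2 by propyl in place of isopropyl on an amide-type nitrogen in a ring, with propyl in place of isopropyl on an amide-type nitrogen in a ring. Within the data shown here, one measured step bears on this change, at the same nitrogen: a number 2 percentage points lower from compound 1 to compound 2 (within the scatter). That step, isopropyl in place of phenyl, stays within the scatter, so nothing points to a real shift in this assay. The expected no change at the digits printed from compound 2 to compound 4 (within the scatter) is no step beyond the scatter. Compound 4 is estimated at 98%, with an expected range of 90% to 100%.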

Compound 4, percent of the compound remaining: 100%
Compound 4: the middle estimate sits 2 percentage points below what was measured, within the range that was stated.
By their numbers in this assay, from the lowest: compounds 2, 1, 3 and 4 (each within the scatter of the next).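

In this assay, propyl in place of isopropyl on the amide-type nitrogen in a ring gives a number 2 percentage points higher from compound 2 to compound 4 (within the scatter) and so adds a third group here that cannot be told apart from the others. Propyl in place of phenyl at the same nitrogen gives no change at the digits printed from compound 1 to compound 4 (within the scatter) and likewise shows no real shift. Nothing available accounts for this result. The compounds shown leave open whether an amine or a longer chain on this nitrogen would also stay within the scatter.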